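This account rests on a few compounds, and the source may have more. Where it says the series, first, only, none or still open, it means among the compounds named here.

Among the compounds with values here, in a functional assay on SK-BR-3 cells (Homo sapiens) for cytotoxicity, read by MTT assay, with a stated time of 72 h (a lower number here means a stronger inhibitor, a higher number a weaker inhibitor), compound 3 `N[C@H]1CC[C@H](Nc2c(C(=O)NCc3ccccc3)nc(Br)c3cccnc23)CC1` gives 8000 nM, the only number available for this small set of compounds. In this assay compound 1 `COC(=O)c1nc(Br)c2cccnc2c1N[C@H]1CC[C@H](N)CC1` stands as "not determined" (no result reported) and compound 2 `N[C@H]1CC[C@H](Nc2c(C(=O)NCc3cccc(C(F)(F)F)c3)nc(Br)c3cccnc23)CC1` stands as "not determined" (no result reported), so compound 3 cannot be ranked against a measured neighbour.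

Compound 4 `N[C@H]1CC[C@H](Nc2c(C(=O)Nc3ccccc3)nc(Br)c3cccnc23)CC1` has yet to be measured in this assay. It departs from compound 3 in a single place: phenyl in place of benzyl on an amide-type nitrogen. This puts phenyl in place of benzyl on an amide-type nitrogen, a change that can also be read as benzylamino to anilino.

Within the data shown here, no measured pair in the set shows what such a change does, so the data offer no direction for it. Among the measured compounds shown here, the only anchor is compound 3 at 8000 nM, and the expectation is therefore for no shift beyond the usual scatter. The expected change is a 1.1-fold lower number from compound 3 to compound 4 (0.06 log units; within the scatter). For compound 4 the estimated value is 7000 nM, with an expected range of 2500 nM to 20000 nM.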

Compound 4, half-maximal inhibitory concentration: 2000 nM
Compound 4: middle estimate off by 3.5-fold (0.54 log units), on the high side; the whole stated range lies above it.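

In this assay, the step gives the first measured direction at this amide-type nitrogen: phenyl in place of benzyl brings a 4.0-fold lower number from compound 3 to compound 4 (0.60 log units; beyond the scatter). The change is small in itself, from 7 heavy atoms to 6, with one six-membered aromatic ring of carbon only on each side and no difference in the counted hydrogen-bond donors or acceptors, so even this slight edit to the group on that nitrogen registers in the read-out. Nothing available explains the step.

The compounds shown leave open whether a longer chain such as phenethyl on the same nitrogen would raise the number further, as a single step cannot establish a trend with chain length. They also leave open how a methoxy group or a chlorine on the phenyl ring of compound 4 would change its value.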